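A few compounds are considered here, and "the series" means these few. Any claim that something is new, unique, unknown or untested is made for them only; others in the source may bear on it.

In a physicochemical assay for lipophilicity (on this read-out higher numbers stand for higher lipophilicity and lower numbers for lower lipophilicity), compound 3 `C[n+]1ccn(COCCCS(C)(=O)=O)c1/C=N/O` gives -2.5. Compound 2 `CC[n+]1ccn(COC(C)C(C)S(C)(=O)=O)c1/C=N/O` gives -2.68, a number close enough to that of compound 3 to fall within the usual scatter, so the two cannot be told apart. Compound 1 `CC(OCn1cc[n+](C)c1/C=N/O)C(C)S(C)(=O)=O` gives -2.09; -2.79 (2 entries), and the several entries of compound 1 in this assay, -2.09; -2.79 (2 entries) shows that its two entries spread more widely than the others. Compound 4 `C[n+]1ccn(COCCCCS(C)(=O)=O)c1/C=N/O` has not yet been measured; it differs from compound 3 by (methylsulfonyl)methyl in place of methylsulfonyl on a saturated chain carbon, three bonds along the chain from an oxygen on a saturated carbon. Going by the values given here, no measured pair in this set shows a change of this kind, so there is no step to lean on. The expected step is small and upward, a number 0.35 log units higher from compound 3 to compound 4 (beyond the scatter), not far beyond the scatter. Compound 4 is therefore estimated at -2.15, with a range from -2.65 to -1.65.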

Compound 4, distribution coefficient: -3.11
Estimate against measurement, compound 4: 0.96 log units above; the measured number lies below the stated range.
By their numbers in this assay, from the lowest: compound 4; then compounds 2 and 3 (each within the scatter of the next).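

In this assay, going by these compounds alone, the first comparison in this set that differs in one place reads a number 0.61 log units lower from compound 3 to compound 4 (beyond the scatter). On a saturated chain carbon, three bonds along the chain from an oxygen on a saturated carbon, (methylsulfonyl)methyl in place of methylsulfonyl therefore moves the number down. This rests on a single pair, and repeat entries for one compound can lie well apart: the several entries of compound 1 in this assay, -2.09; -2.79 (2 entries)

From the compounds shown here alone, whether 2-(methylsulfonyl)ethyl at this place would continue the fall remains open. So does the effect on this read-out of replacing the sulfone end with a carboxylic acid or an amine.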